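Halogenated phenyl ureas: estimating the 2-fluorophenyl member

The source may report more compounds than this note shows. Statements on the series, on what has been measured and on what is new or still open speak of the compounds shown alone.

Three compounds have been measured so far in a functional assay on T-24 cells (Homo sapiens) for antiproliferative activity, read by MTT assay, with a stated time of 48 h (on this read-out lower numbers stand for stronger inhibition and higher numbers for weaker inhibition), and give these values:

- compound 1 `O=C(Nc1ccccc1)Nc1cccc(CNc2nccnc2Cl)c1` gives 19800 nM
- compound 2 `O=C(Nc1ccc(Cl)cc1)Nc1cccc(CNc2nccnc2Cl)c1` gives 5470 nM
- compound 3 `O=C(Nc1cccc(CNc2nccnc2Cl)c1)Nc1ccc(F)c(Cl)c1` gives 4990 nM

Compound 3 belongs to the low pair of the three. Its gap to the other halogenated member stays within the scatter (a 1.1-fold lower number from compound 2 to compound 3 (0.04 log units; within the scatter)), while its gap to the plain phenyl member lies beyond it (a 4.0-fold lower number from compound 1 to compound 3 (0.60 log units; beyond the scatter)).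

Compound 4 `O=C(Nc1cccc(CNc2nccnc2Cl)c1)Nc1ccccc1F` is still unmeasured. It has 2-fluorophenyl in place of 3-chloro-4-fluorophenyl on an amide-type nitrogen and the rest of the structure is unchanged.

Going by the values given here, no measured compound carries 2-fluorophenyl, so the evidence is indirect. Adding chloro to the plain phenyl gave a modest step (a 3.6-fold lower number from compound 1 to compound 2 (0.56 log units; beyond the scatter)), and the step to compound 3 quoted above is of similar size. Compound 4 keeps one halogen but loses the chloro present in compound 3, so part of that modest gain may be given back. A small move to a higher number is expected, possibly close to the scatter. a 2.0-fold higher number from compound 3 to compound 4 (0.30 log units; within the scatter) is the estimated change. For compound 4 the expected value is 10000 nM with 4500 nM to 20000 nM as the estimated range.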

Compound 4, half-maximal inhibitory concentration: 7450 nM
The estimate for compound 4 lay 1.3-fold (0.13 log units) above the measured number, within the range that was stated.
By their numbers in this assay, from the lowest: compounds 3, 2 and 4 (each within the scatter of the next); then compound 1.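

Notes on the position: in this assay, one fluoro on the phenyl ring is enough to leave the level of the plain phenyl member, with a 2.7-fold lower number from compound 1 to compound 4 (0.42 log units; beyond the scatter) as the step. Chloro is therefore not needed for this shift, which the earlier compounds could not show, since both halogenated members carried it. Replacing the 3-chloro-4-fluorophenyl on the amide-type nitrogen with 2-fluorophenyl gives a 1.5-fold higher number from compound 3 to compound 4 (0.17 log units; within the scatter) and replacing 4-chlorophenyl with it gives a 1.4-fold higher number from compound 2 to compound 4 (0.13 log units; within the scatter), so both steps stay within the scatter and the three halogenated groups cannot be told apart at this position, while all three differ from plain phenyl.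

Still open, on these data alone, is whether this shared level is specific to halogens, as a methoxy, trifluoromethyl or nitrile group on the same phenyl ring, or an amine or carboxylic acid there, would test, and whether 4-fluorophenyl or 2-chlorophenyl would sit at the same level. The data shown offer no independent measurement that accounts for the shift from plain phenyl or for the likeness of the halogenated members.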